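A few compounds are considered here, and "the series" means these few. Any claim that something is new, unique, unknown or untested is made for them only; others in the source may bear on it.

The series begins with compound 1 `C=CCSc1nnc(CC)n1N1C(=O)c2ccccc2C1=O`, whose sulfur carries a short chain ending in a vinyl group. In a functional assay on MKN-45 cells (Homo sapiens) for cytotoxicity, read by MTT assay, with a stated time of 48 h (a higher number here means a weaker inhibitor, a lower number a stronger inhibitor), compound 1 gives only a limit of the measurement, > 200000 nM. Compound 2 `CCc1nnc(SCC(=O)c2ccccc2)n1N1C(=O)c2ccccc2C1=O` keeps the shared core and puts a benzoyl in place of the vinyl on the chain carbon bound to the sulfur. In this assay compound 2 again gives only a limit, > 200000 nM. The step that the two limits leave unreadable from compound 1 to compound 2 therefore cannot be read, and compound 2 stands exactly where the other measured compound stands, at the limit of > 200000 nM in this assay, at which 2 of the 2 values shown sit, with no finer number to place it.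

Compound 3 `CCc1nnc(SCC(=O)c2ccc(Cl)cc2)n1N1C(=O)c2ccccc2C1=O` is the next variation: chloro in place of hydrogen on an aromatic carbon, the chlorine entering on the six-membered aromatic ring para to a large group. Among the measured compounds shown here, the only measured step that bears on this change is a step that the two limits leave unreadable from compound 1 to compound 2, and it has no readable size, so no direction of change beyond the scatter can be expected from it. Compound 3 is therefore estimated at 250000 nM, within 50000 nM to 1000000 nM, most likely once more as a limit. The expected step that the limit leaves unreadable from compound 2 to compound 3 is accordingly small.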

Compound 3, half-maximal inhibitory concentration: > 200000 nM
Compound 3: only a limit was reported (the forecaster's own chance of this, stated with the estimate: 80%); the middle value is on the limit's open side.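

In this assay compound 3 also gives only a limit, > 200000 nM. The steps to compound 3 from compound 1 and from compound 2 therefore cannot be read, and the three compounds stand together: the limit of > 200000 nM in this assay, at which 3 of the 3 values shown sit.

The compounds shown leave open what actual value each one has, and so whether the benzoyl or chloro change has any effect in this assay.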